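The source may hold more compounds than are shown below. What is called first, only, known or untested is meant among the compounds shown, and "the series" means these compounds.

Measured compounds:
Compound 1, `COc1cc(-c2cc(/C=C/C(=O)c3ccc(N)cc3)[nH]n2)cc(OC)c1OC`, in a functional assay on SK-MEL-2 cells (Homo sapiens) for inhibition, read by sulforhodamine B assay, with a stated time of 48 h (on this read-out lower numbers stand for higher toxicity in this test and higher numbers for lower toxicity in this test), compound 1 gives 31900 nM.
Compound 2, `COc1ccc(-c2cc(/C=C/C(=O)c3ccc(N)cc3)[nH]n2)cc1OC`, in this assay compound 2 gives 53200 nM.
Compound 3, `COc1cc(C(=O)/C=C/c2cc(-c3cc(OC)c(OC)c(OC)c3)n[nH]2)cc(OC)c1OC`, in this assay compound 3 gives 8320 nM.

Compound 1 and compound 2 share a core and differ in one place: hydrogen in place of methoxy on an aromatic carbon. In this assay this change gave a 1.7-fold higher number from compound 1 to compound 2 (0.22 log units; within the scatter), so the two compounds cannot be told apart on this read-out.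

Compound 3 is built on a different core; how its core differs from that of compound 1 is not broken down here. In this assay compound 3 stands at the lowest number of the three, with its steps to compound 1 and to compound 2 both beyond the scatter.

Compound 4, `COc1ccc(-c2cc(/C=C/C(=O)c3cc(OC)c(OC)c(OC)c3)[nH]n2)cc1OC`, is not yet measured. It differs from compound 3 by hydrogen in place of methoxy on an aromatic carbon. The place of the change is described in the same words as for the step from compound 1 to compound 2, so it is the same change, made on the core of compound 3 instead.

The expectation for compound 4 rests on compound 3, because its value 8320 nM is the starting point, and on the earlier pair, because the step of a 1.7-fold higher number from compound 1 to compound 2 (0.22 log units; within the scatter) was small. Compound 4 is therefore expected to show a step of about a 1.6-fold higher number from compound 3 to compound 4 (0.19 log units; within the scatter) in this assay. Compound 4 is estimated at 13000 nM, expected between 6000 nM and 30000 nM.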

Compound 4, concentration lethal to 50% of the cells: 29500 nM
Compound 4: the middle estimate sits 2.3-fold (0.36 log units) below what was measured, and the stated range covers the measured number.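

On the core of compound 3, putting hydrogen in place of methoxy gave a 3.5-fold higher number from compound 3 to compound 4 (0.55 log units; beyond the scatter) in this assay, a step that on its own lies beyond the scatter, whereas the same change on the core of compound 1 did not separate its two compounds. Set side by side, the two steps cannot be told apart, so there is no sign here that the core alters the size of this step: the same change on two cores in this assay, a 1.7-fold higher number (0.22 log units; within the scatter) from compound 1 to compound 2 and a 3.5-fold higher number (0.55 log units; beyond the scatter) from compound 3 to compound 4, 2.1-fold (0.33 log units) apart, within the scatter of two such steps. Within the data shown here, this shows only that the two cores are compatible with a common step, and it does not show that the step is truly equal on both, since two pairs in a single test leave a real but modest difference undetected, nor does it show how the change would behave on any further core.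

Both pairs exchange methoxy for hydrogen alone, so the compounds shown leave open what a hydroxyl group, a fluorine or chlorine atom, or a longer ether chain such as ethoxy would do on the same aromatic carbon in this assay. They also leave open whether the step seen here would be repeated on other cell lines or at other exposure times.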